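A few compounds are considered here, and "the series" means these few. Any claim that something is new, unique, unknown or untested is made for them only; others in the source may bear on it.

Compound 1 `CC1=C(C)C(=O)C(C(CCCCCCC(=O)O)c2ccccc2)=C(C)C1=O`: 3200 nM
Compound 2 `CC1=C(C)C(=O)C(C(CCCCCC(=O)O)c2ccc(C)cc2)=C(C)C1=O`: 1000 nM
Compound 3 `CC1=C(C)C(=O)C(C(CCCCCC(=O)O)c2ccccc2C)=C(C)C1=O`: 3200 nM
Compound 4 `COc1ccc(C(CCCCCC(=O)O)C2=C(C)C(=O)C(C)=C(C)C2=O)cc1`: not yet measured

In a functional assay (aorta) with Oryctolagus cuniculus as the target (on this read-out higher numbers stand for weaker inhibition and lower numbers for stronger inhibition), compound 3, at 3200 nM, stands level with compound 1, at 3200 nM. Together they hold the highest number so far. Compound 4 carries 4-methoxyphenyl in place of 2-methylphenyl on a saturated chain carbon bound to a double-bonded ring carbon and a saturated chain carbon. For the measured compounds named here, the only measured step bearing on this is a 3.2-fold higher number from compound 2 to compound 3 (0.51 log units; beyond the scatter), where 2-methylphenyl replaced 4-methylphenyl. Going by the values given here, no methoxy compound has been measured, so the reverse direction is only an expectation, with compound 2 at 1000 nM as the guide. The expected step is a 2.7-fold lower number from compound 3 to compound 4 (0.43 log units; beyond the scatter), of similar size to the measured one. For compound 4 the estimate in this assay is 1200 nM, with an expected range of 400 nM to 3200 nM.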

Compound 4, half-maximal inhibitory concentration: 3000 nM
Beside the measured number, compound 4's estimate is 2.5-fold (0.40 log units) below it; the range from low to high includes it.
By their numbers in this assay, from the lowest: compound 2; then compounds 4, 1 and 3 (each within the scatter of the next).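

In this assay, methoxy in place of methyl on an aromatic carbon gives a 3.0-fold higher number from compound 2 to compound 4 (0.48 log units; beyond the scatter), so the low number of compound 2 does not carry over to this close analogue. With 4-methoxyphenyl in place of 2-methylphenyl, the result is a 1.1-fold lower number from compound 3 to compound 4 (0.03 log units; within the scatter), and the two groups cannot be told apart on this read-out. Nothing available explains either step. Still open, as far as these compounds go, is whether a hydroxyl or a chlorine on an aromatic carbon would read with compound 2 or with compound 4. Also open, from the compounds shown here alone, is whether 4-methylphenyl with a longer chain would keep the number of compound 2.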